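This account rests on a few compounds, and the source may have more. Where it says the series, first, only, none or still open, it means among the compounds named here.

The measured compounds, all sharing one core:

Compound 1, `Cc1cc(NC(=O)Cn2nnc(-c3ccccc3)n2)n(C2CCCC2)n1`, gives 105% in an assay on HEK293 cells for activation of Kir3.1/Kir3.2 (Homo sapiens), read by thallium flux; a higher number here means a larger maximal response, a lower number a smaller maximal response.
Compound 2, `Cc1cc(NC(=O)Cn2nnc(-c3ccccc3)n2)n(C2CCS(=O)(=O)CC2)n1`, gives only a limit of this assay, > 25%.
Compound 3, `Cc1cc(NC(=O)Cn2nnc(-c3ccccc3)n2)n(CC2CCCCC2)n1`, gives 77%.

Compound 3 stands lowest of the two readable numbers. Its nearest neighbour is compound 1, and the step between them is a number 28 percentage points lower from compound 1 to compound 3 (beyond the scatter). The step from compound 1 to compound 2 and the step from compound 2 to compound 3 cannot be sized, since compound 2 sits at the limit of > 25% in this assay, at which 1 of the 3 values shown sits.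

Compound 4, `Cc1cc(NC(=O)Cn2nnc(-c3ccccc3)n2)n(-c2ccccc2)n1`, differs from compound 3 in one place: phenyl in place of cyclohexylmethyl on an aromatic nitrogen. Among the compounds with values here, no measured step exchanges a saturated ring for an aromatic one on that nitrogen, so the only guide is the step from compound 1 to compound 3, a number 28 percentage points lower from compound 1 to compound 3 (beyond the scatter), a modest loss when the substituent on that nitrogen was changed. A change of similar size, or none beyond the scatter, is therefore expected here, with the direction open. The expected step from compound 3 to compound 4 in this assay is a number 3 percentage points higher from compound 3 to compound 4 (within the scatter). Compound 4 is estimated to reach 80% in this assay, within a range from 45% to 110%.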

Compound 4, largest response reached (Emax), in percent of the reference or control that the assay uses: 66%
Beside the measured number, compound 4's estimate is 14 percentage points above it, and the stated range covers the measured number.
By their numbers in this assay, from the lowest: compound 4; then compound 3; then compound 1.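

Placing phenyl on the aromatic nitrogen puts an aromatic ring at this position, and in this assay the result is a number 11 percentage points lower from compound 3 to compound 4 (beyond the scatter), together with a number 39 percentage points lower from compound 1 to compound 4 (beyond the scatter). Cyclohexylmethyl and phenyl each count no hydrogen-bond donors or acceptors and no net charge, and both are six-membered rings of carbon only, so this position separates two such groups by more than the scatter, one non-aromatic and the other aromatic. The earlier loss on leaving cyclopentyl is therefore not confined to cyclohexylmethyl: among the readable numbers, both replacements of cyclopentyl fall short of compound 1, and phenyl falls furthest.

Compound 2 gives only a limit, and the steps that involve it cannot be read: the limit of > 25% in this assay, at which 1 of the 4 values shown sits.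

Whether a phenyl ring carrying an amine, a methoxy group or a fluorine would give a response closer to that of compound 1 stays open, as does what lies behind the gap between phenyl and cyclohexylmethyl.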